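The compounds below may be only part of what the source reports. "The series", "measured", "known", "first", "only" and "open" are said of these compounds alone.

Working notes on the series. The shared core is that of compound 1 `Nc1ccc(-c2cc(=O)c3c(N)c(F)c(CO)c(F)c3o2)cc1F`, and the members differ only in the group on a saturated chain carbon bound to an aromatic carbon. In a functional assay on HeLa cells (Homo sapiens) for cytotoxicity, read by neutral red uptake, with a stated time of 3 days (on this read-out higher numbers stand for weaker inhibition and lower numbers for stronger inhibition), compound 1 gives 24000 nM. Compound 2 `COCc1c(F)c(N)c2c(=O)cc(-c3ccc(N)c(F)c3)oc2c1F` carries a methyl in place of the hydroxyl hydrogen of compound 1. In this assay compound 2 gives > 100000 nM, which is a limit of the assay and not a number. Compound 3 `CCCCCCOCc1c(F)c(N)c2c(=O)cc(-c3ccc(N)c(F)c3)oc2c1F` carries a hexyl in that same place. In this assay compound 3 gives > 100000 nM, again a limit of the assay, so compound 3 has no number of its own. Two of the three values sit at the limit of > 100000 nM in this assay, at which 2 of the 3 values shown sit. The steps from the hydroxyl read an at least 4.1-fold higher number from compound 1 to compound 2 (0.61 log units; beyond the scatter) and an at least 4.1-fold higher number from compound 1 to compound 3 (0.61 log units; beyond the scatter), while between the two ethers a step that the two limits leave unreadable from compound 2 to compound 3. Compound 4 `CN(C)Cc1c(F)c(N)c2c(=O)cc(-c3ccc(N)c(F)c3)oc2c1F` is the next member: dimethylamino in place of hexyloxy on a saturated chain carbon bound to an aromatic carbon. Within the data shown here, both readable steps at this position moved toward weaker inhibition once the hydroxyl hydrogen was replaced, and no step separates the two ethers. Compound 4 is therefore expected to sit near the limit as well, with a fair chance that only a limit is reported, an expected step of an at least 1.6-fold lower number from compound 3 to compound 4 (0.22 log units; that floor lies within the scatter). The estimate for compound 4 is 60000 nM, with a range from 15000 nM to 200000 nM.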

Compound 4, half-maximal inhibitory concentration: 8900 nM
Compound 4: the middle estimate sits 6.7-fold (0.83 log units) above what was measured; the whole stated range lies above it.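

In this assay, the group on a saturated chain carbon bound to an aromatic carbon proves able to move the read-out toward stronger inhibition as well as weaker: dimethylamino in place of hexyloxy gives an at least 11-fold lower number from compound 3 to compound 4 (1.05 log units; beyond the scatter), and dimethylamino in place of methoxy gives an at least 11-fold lower number from compound 2 to compound 4 (1.05 log units; beyond the scatter). The change also improves on the free hydroxyl, which neither ether did, with a 2.7-fold lower number from compound 1 to compound 4 (0.43 log units; beyond the scatter). Compound 4 is therefore the strongest of the four shown, while the two steps from the ethers are floors and not full sizes, as each starts from a limit of the assay: the limit of > 100000 nM in this assay, at which 2 of the 4 values shown sit.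

The compounds shown leave open whether the nitrogen itself or the two methyl groups on it carry the step, and an unsubstituted amine or a diethylamino group on this same carbon would bear on that. They also leave open whether any other group here would read on the side of stronger inhibition, such as a carboxylic acid or an amine on a longer chain.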